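The compounds below may be only part of what the source reports. "The series", "measured", "known", "first", "only" and "open" are said of these compounds alone.

Compound 3, `COc1cc(-c2noc([C@H](C)NC(=O)c3cc(C(F)(F)F)nn3C)n2)ccn1`, gives 27 nM in an assay on T-REx-293 cells for inhibition of potassium channel subfamily T member 1 (Homo sapiens), read by patch clamp (a higher number here means a weaker inhibitor, a lower number a stronger inhibitor), the lowest of the three numbers measured here. Its nearest neighbour is compound 2, `Cc1cc(-c2noc([C@H](C)NC(=O)c3cc(C(F)(F)F)nn3C)n2)ncn1`, which in this assay gives 1410 nM; the gap between them is a 52-fold lower number from compound 2 to compound 3 (1.72 log units; beyond the scatter). Furthest away is compound 1, `C[C@H](NC(=O)c1cc(C(F)(F)F)nn1C)c1nc(-c2ccncc2)no1`, which in this assay gives 5250 nM; from it to compound 3 the step is a 190-fold lower number from compound 1 to compound 3 (2.29 log units; beyond the scatter), and from it to compound 2 the step is a 3.7-fold lower number from compound 1 to compound 2 (0.57 log units; beyond the scatter).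

Compound 4, `C[C@H](NC(=O)c1cc(C(F)(F)F)nn1C)c1nc(-c2ccnc(C(F)F)c2)no1`, differs from compound 3 in one place: difluoromethyl in place of methoxy on an aromatic carbon. The measured steps that touch this position are those in which methoxy enters, a 190-fold lower number from compound 1 to compound 3 (2.29 log units; beyond the scatter) and a 52-fold lower number from compound 2 to compound 3 (1.72 log units; beyond the scatter), both large. Compound 4 does not return to hydrogen but carries difluoromethyl, a group without a hydrogen-bond acceptor, so some of the gain of compound 3 is expected to be lost, though not all of it. Compound 4 is therefore expected to give an estimated 300 nM, with a range from 60 nM to 1500 nM. That estimate means an expected step of an 11-fold higher number from compound 3 to compound 4 (1.05 log units; beyond the scatter).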

Compound 4, half-maximal inhibitory concentration: 61 nM
Compound 4: the middle estimate sits 4.9-fold (0.69 log units) above what was measured; measured number inside the range.
By their numbers in this assay, from the lowest: compound 3; then compound 4; then compound 2; then compound 1.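

In this assay, a group with no hydrogen-bond acceptor also delivers most of the gain at this position next to the ring nitrogen, with an 86-fold lower number from compound 1 to compound 4 (1.93 log units; beyond the scatter), so a large gain here does not require an acceptor in the entering group. Replacing methoxy with difluoromethyl gives only a modest loss, a 2.3-fold higher number from compound 3 to compound 4 (0.35 log units; beyond the scatter), and the difluoromethyl compound keeps a large lead over the 6-methylpyrimidin-4-yl compound, with a 23-fold lower number from compound 2 to compound 4 (1.36 log units; beyond the scatter). Nothing measured here explains why two such different groups both give large gains.

As far as these compounds go, how an amine, a chlorine or an ethoxy at this same position would compare remains open. Also open, from the compounds shown here alone, is whether either group would give a similar gain on the 6-methylpyrimidin-4-yl ring of compound 2.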